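This account rests on a few compounds, and the source may have more. Where it says the series, first, only, none or still open, it means among the compounds named here.

Series notes, a functional assay on HeLa cells (Homo sapiens) for cytotoxicity, read by MTT assay; a lower number here means a stronger inhibitor, a higher number a weaker inhibitor. Compound 3 `CC(C)=CC[C@@H](OC(=O)CCO)C1=CC(=O)c2c(O)ccc(O)c2C1=O` gives 67600 nM and carries the highest number of the three measured, with compound 1 `CC(=O)OCCC(=O)O[C@H](CC=C(C)C)C1=CC(=O)c2c(O)ccc(O)c2C1=O` at 17300 nM and compound 2 `CC(C)=CC[C@@H](OC(=O)C1CCCO1)C1=CC(=O)c2c(O)ccc(O)c2C1=O` at 17000 nM; the gaps a 3.9-fold higher number from compound 1 to compound 3 (0.59 log units; beyond the scatter) and a 4.0-fold higher number from compound 2 to compound 3 (0.60 log units; beyond the scatter) are both beyond the scatter. Compound 4 `CCC(O)CO[C@H](CC=C(C)C)C1=CC(=O)c2c(O)ccc(O)c2C1=O` is the next, unmeasured, member: 2-hydroxybutyl in place of (2-hydroxyethyl)carbonyl on an oxygen on a saturated carbon. Among the measured compounds shown here, no measured step swaps the ester for an ether; the nearest guides are the acyl changes a 1.0-fold lower number from compound 1 to compound 2 (0.01 log units; within the scatter), within the scatter, and the acetyl loss a 3.9-fold higher number from compound 1 to compound 3 (0.59 log units; beyond the scatter), modest. A change of at most modest size in this assay is therefore expected, leaning to a lower number, as a 1.5-fold lower number from compound 3 to compound 4 (0.18 log units; within the scatter). Compound 4 is estimated at 45000 nM, with a range of 15000 nM to 130000 nM.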

Compound 4, half-maximal inhibitory concentration: 28700 nM
For compound 4 the middle estimate is 1.6-fold (0.20 log units) above the measured one; the measured number falls inside the stated range.
By their numbers in this assay, from the lowest: compounds 2, 1 and 4 (each within the scatter of the next); then compound 3.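

In this assay, the 2-hydroxybutyl ether in place of the (2-hydroxyethyl)carbonyl ester gives a 2.4-fold lower number from compound 3 to compound 4 (0.37 log units; beyond the scatter) and so shows that an acyl carbonyl is not needed on this oxygen. Against the other two esters, the ether gives a 1.7-fold higher number from compound 2 to compound 4 (0.23 log units; within the scatter) and a 1.7-fold higher number from compound 1 to compound 4 (0.22 log units; within the scatter) and leaves compound 3 alone apart from the other three. Nothing available explains these steps.

Compound 4 is the only ether shown, so the role of its chain hydroxyl remains open. Also open, on these data alone, is how an amine, a carboxylic acid or a longer chain would read at this oxygen.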